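This account rests on a few compounds, and the source may have more. Where it says the series, first, only, none or still open, it means among the compounds named here.

In a functional assay on MGC-803 cells (Homo sapiens) for antiproliferative activity, read by MTT assay, with a stated time of 48 h (on this read-out higher numbers stand for weaker inhibition and lower numbers for stronger inhibition), compound 1 `O=C(Nc1ccccc1)Nc1cccc(CNc2nccnc2Cl)c1` gives 16300 nM and compound 2 `COc1ccccc1NC(=O)Nc1cccc(CNc2nccnc2Cl)c1` gives 12200 nM while compound 3 `CCc1ccccc1NC(=O)Nc1cccc(CNc2nccnc2Cl)c1` gives 9370 nM on the same read-out. Compound 3 stands within the scatter of both others, with a 1.7-fold lower number from compound 1 to compound 3 (0.24 log units; within the scatter) and a 1.3-fold lower number from compound 2 to compound 3 (0.11 log units; within the scatter) as its steps. Compound 4 `Cc1ccc(NC(=O)Nc2cccc(CNc3nccnc3Cl)c2)cc1C` has the same atoms as compound 3, joined differently: 3,4-dimethylphenyl in place of 2-ethylphenyl on an amide-type nitrogen. With a 1.3-fold lower number from compound 1 to compound 2 (0.13 log units; within the scatter) as well, every measured step stays within the scatter and none makes this exchange, so no step beyond the scatter is expected in this assay in either direction. The expected step is a 1.1-fold higher number from compound 3 to compound 4 (0.03 log units; within the scatter) as an estimate only. Compound 4 is expected at 10000 nM within an estimated range of 4000 nM to 22000 nM for now.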

Compound 4, half-maximal inhibitory concentration: 9870 nM
Compound 4: the middle estimate sits 1.0-fold (0.01 log units) above what was measured, within the range that was stated.
By their numbers in this assay, from the lowest: compounds 3, 4, 2 and 1 (each within the scatter of the next).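

In this assay the exchange of 2-ethylphenyl for 3,4-dimethylphenyl on the amide-type nitrogen gives a 1.1-fold higher number from compound 3 to compound 4 (0.02 log units; within the scatter) and so does not separate these two arrangements of the same atoms. The other steps to compound 4 are a 1.2-fold lower number from compound 2 to compound 4 (0.09 log units; within the scatter) and a 1.7-fold lower number from compound 1 to compound 4 (0.22 log units; within the scatter) so 3,4-dimethylphenyl also stays within the scatter of 2-methoxyphenyl and phenyl at this place. No measurement on hand gives a reason for these steps. Open, on these data alone, is whether an amine or a carboxylic acid on the phenyl, or a longer chain in place of ethyl, would give a step beyond the scatter.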